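This account rests on a few compounds, and the source may have more. Where it says the series, first, only, none or still open, it means among the compounds named here.

Measured compounds: compound 1 `COc1cc(-c2nn(-c3cccc(NC(=O)Nc4cc(C(F)(F)F)cc(C(F)(F)F)c4)c3)cc2-c2ccncc2)ccc1Cl` gives 26200 nM in a functional assay on UACC-257 cells (Homo sapiens) for inhibition, read by sulforhodamine B assay, with a stated time of 48 h; on this read-out lower numbers stand for higher toxicity in this test and higher numbers for lower toxicity in this test; compound 3 `COc1cc(-c2nn(-c3cccc(NC(=O)Nc4cccc(C(F)(F)F)c4)c3)cc2-c2ccncc2)ccc1Cl` gives 7580 nM. Compound 2 `COc1cc(-c2nn(-c3cccc(NC(=O)Nc4ccc(Cl)c(Cl)c4)c3)cc2-c2ccncc2)ccc1Cl` gives only the limit > 50000 nM, a boundary of the test rather than a number.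

Among the two numbers shown, compound 3 carries the lowest one, with compound 1 the nearest (a 3.5-fold lower number from compound 1 to compound 3 (0.54 log units; beyond the scatter)). The step from compound 2 to compound 3 cannot be sized exactly because the limit of > 50000 nM in this assay, at which 1 of the 3 values shown sits, is a limit, yet it reads as an at least 6.5-fold lower number from compound 2 to compound 3 (0.81 log units; beyond the scatter).

Compound 4 `COc1cc(-c2nn(-c3cccc(NC(=O)Nc4ccc(Cl)c(C(F)(F)F)c4)c3)cc2-c2ccncc2)ccc1Cl` is not yet measured. It differs from compound 3 by chloro in place of hydrogen on an aromatic carbon. Going by the values given here, both measured steps that end at compound 3 point the same way: removing a trifluoromethyl (a 3.5-fold lower number from compound 1 to compound 3 (0.54 log units; beyond the scatter)) and exchanging 3,4-dichlorophenyl for 3-(trifluoromethyl)phenyl (an at least 6.5-fold lower number from compound 2 to compound 3 (0.81 log units; beyond the scatter)) each lowered the number, so the extra chloro in compound 4 is expected to raise it, probably by a modest step beyond the scatter, though the exact pairing of chloro with trifluoromethyl has no direct precedent here. The step from compound 3 to compound 4 is therefore estimated as a 1.7-fold higher number from compound 3 to compound 4 (0.23 log units; within the scatter). Compound 4 is expected to give about 13000 nM, between 4000 nM and 42000 nM.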

Compound 4, concentration lethal to 50% of the cells: 29200 nM
Compound 4: middle estimate off by 2.2-fold (0.35 log units), on the low side; measured number inside the range.
By their numbers in this assay, from the lowest: compound 3; then compounds 1 and 4 (each within the scatter of the next). At a limit, above all of these: compound 2.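

Adding a single chloro to the ring that carries the trifluoromethyl, ortho to that group and para to a large group, gives the first direct reading of this position in this assay: a 3.9-fold higher number from compound 3 to compound 4 (0.59 log units; beyond the scatter), which means lower toxicity in this test, although compound 1, which has no chloro there, shows that this is not the only change that raises the number. The other change on this ring, trifluoromethyl in place of chloro on an aromatic carbon, reads as an at least 1.7-fold lower number from compound 2 to compound 4 (0.23 log units; that floor lies within the scatter), so it shows no clear difference between the two groups on that carbon. Compound 2 gives a limit and not a number, so this second step has no exact size: the limit of > 50000 nM in this assay, at which 1 of the 4 values shown sits.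

Going by these compounds, whether the rise belongs to chloro alone or would also follow from another group at this position, such as a fluoro, a methyl or an amine, stays open. The compounds shown also leave open whether the same change would give the same step in any other cell line.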